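Cytotoxicity notes: the step from compound 2 to compound 3

A few compounds are considered here, and "the series" means these few. Any claim that something is new, unique, unknown or untested is made for them only; others in the source may bear on it.

The series has two entries so far in an ADME assay on L6 cells (Rattus norvegicus) for cytotoxicity, read by resazurin assay, with a stated time of 70 h; a lower number here means a stronger inhibitor, a higher number a weaker inhibitor. Compound 1 (`COc1cc(NC(C)CCCNC(=O)NC2CCCC2)c2ncccc2c1`) stands as "not determined" (no result reported), so it offers no number for comparison. Within the data shown here, compound 2 (`COc1cc(NC(C)CCCNC(=O)NNC(=O)/C(C)=C/c2ccccc2)c2ncccc2c1`) gives 36500 nM, the only number available, so it cannot yet be ranked against anything. Compound 3 (`COc1cc(NC(C)CCCNC(=O)NNC(=O)/C=C/c2cccc(C(F)(F)F)c2)c2ncccc2c1`) keeps the shared core and changes one group, on a carbonyl carbon whose other neighbour is an amide-type nitrogen: 2-(3-(trifluoromethyl)phenyl)ethenyl in place of 1-methyl-2-phenylethenyl (2-(3-(trifluoromethyl)phenyl)ethenyl in place of 1-methyl-2-phenylethenyl on a carbonyl carbon). Among the measured compounds shown here, no measured step gauges this kind of change, which leaves compound 2 at 36500 nM as the sole anchor. The estimate means a 1.5-fold lower number from compound 2 to compound 3 (0.16 log units; within the scatter), an expected small move toward a lower number that stays within the scatter. For compound 3 the expected value in this assay is 25000 nM, with an estimated range of 8000 nM to 80000 nM.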

Compound 3, half-maximal inhibitory concentration: 10600 nM
For compound 3 the middle estimate is 2.4-fold (0.37 log units) above the measured one, and the stated range covers the measured number.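

In this assay the series now has its first measured step, a 3.4-fold lower number from compound 2 to compound 3 (0.54 log units; beyond the scatter), so the group on the carbonyl carbon does affect the read-out, by more than the usual scatter. The swap makes two changes at once, since the methyl of 1-methyl-2-phenylethenyl goes and a trifluoromethyl arrives on the phenyl ring, and this single step cannot separate them. No measurement shown here accounts for the step.

Still open, on these data alone, is which of the two changes carries the step; a plain 2-phenylethenyl group, with neither the methyl nor the trifluoromethyl, would divide them. Also open, as far as these compounds go, is how the read-out responds when the ethenyl linker gives way to a saturated two-carbon chain, or when the trifluoromethyl gives way to a carboxylic acid.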